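From 3-chlorophenyl to 4-chlorophenyl on a shared core

A few compounds are considered here, and "the series" means these few. Any claim that something is new, unique, unknown or untested is made for them only; others in the source may bear on it.

Measured so far in a functional assay on OVCAR-3 cells (Homo sapiens) for cytotoxicity, read by sulforhodamine B assay (on this read-out lower numbers stand for higher toxicity in this test and higher numbers for lower toxicity in this test), on this series:
Compound 1 `CC1=CC[C@@H]([C@@](C)(O)CCCC(C)(C)NC(=S)N/N=C\c2ccccc2Cl)CC1` gives > 100000 nM as a limit of the assay
Compound 2 `CC1=CC[C@@H]([C@@](C)(O)CCCC(C)(C)NC(=S)N/N=C\c2cccc(Cl)c2)CC1` gives 48000 nM as a number

Compound 2 stands alone with a true number, 48000 nM in this pair. Compound 1 offers only a limit, recorded as the limit of > 100000 nM in this assay, at which 1 of the 2 values shown sits, for this series. Compound 3 `CC1=CC[C@@H]([C@@](C)(O)CCCC(C)(C)NC(=S)N/N=C\c2ccc(Cl)cc2)CC1` differs from compound 2 as follows: 4-chlorophenyl in place of 3-chlorophenyl on a carbon with a double bond to nitrogen and so carries 4-chlorophenyl in place of 3-chlorophenyl on a carbon with a double bond to nitrogen.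

Going by the values given here, one measured step bears on this change, an at least 2.0-fold lower number from compound 1 to compound 2 (0.31 log units; beyond the scatter) for 3-chlorophenyl in place of 2-chlorophenyl, and it starts from a limit. It shows that a swap of this kind can move the number, but it gives no direction for the next swap. Compound 2 with 48000 nM therefore serves as the anchor, and only a small step in no firm direction, quite possibly within the scatter, is expected in this assay here. The estimated change is a 1.1-fold lower number from compound 2 to compound 3 (0.03 log units; within the scatter) as the expected outcome. Compound 3 is expected near 45000 nM as an estimate, with a likely range from 15000 nM to 100000 nM on this read-out.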

Compound 3, concentration lethal to 50% of the cells: 40600 nM
Beside the measured number, compound 3's estimate is 1.1-fold (0.04 log units) above it; the range from low to high includes it.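

In this assay, the step of a 1.2-fold lower number from compound 2 to compound 3 (0.07 log units; within the scatter) shows that at this place, on a carbon with a double bond to nitrogen, 4-chlorophenyl and 3-chlorophenyl cannot be told apart, something the earlier pair could not show. The step of an at least 2.4-fold lower number from compound 1 to compound 3 (0.39 log units; beyond the scatter) also starts from a limit and, like the earlier step, is printed as beyond the scatter, so 2-chlorophenyl now stands apart from both other chlorophenyl groups, and not from just one of them. From the compounds shown here alone, how far it stands apart stays unknown, as the value for compound 1 is a limit and not a number: the limit of > 100000 nM in this assay, at which 1 of the 3 values shown sits.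

The compounds shown differ only in where the chlorine sits on the phenyl ring, so they leave open how an unsubstituted phenyl, a methoxyphenyl, a nitrile-bearing phenyl or a pyridine ring would read at this place. They also say nothing about whether the change would read the same on a core without the hydroxyl group, or with a longer chain.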